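Quinolin-4-yl in Place of Methoxybenzofuranyl on the Amide

A few compounds are considered here, and "the series" means these few. Any claim that something is new, unique, unknown or untested is made for them only; others in the source may bear on it.

Among the measured compounds shown here, compound 3 `COc1cccc2cc(C(=O)N[C@H](CCCNC(=N)N)C(=O)NCc3ccc(C(F)(F)F)cc3)oc12` gives 622 nM in a functional assay on HEK293 cells for antagonist activity at melanin-concentrating hormone receptor 1 (Homo sapiens) (a higher number here means a weaker inhibitor, a lower number a stronger inhibitor), the second highest of the three numbers measured so far. Compound 1 `N=C(N)NCCC[C@@H](NC(=O)c1cnc2ccccc2c1)C(=O)NCc1ccc(C(F)(F)F)cc1` gives 96 nM and compound 2 `N=C(N)NCCC[C@@H](NC(=O)c1cc2ccccc2cn1)C(=O)NCc1ccc(C(F)(F)F)cc1` gives 1810 nM, so compound 3 sits between them: a 6.5-fold higher number from compound 1 to compound 3 (0.81 log units; beyond the scatter) and a 2.9-fold lower number from compound 2 to compound 3 (0.46 log units; beyond the scatter). Compound 4 `N=C(N)NCCC[C@@H](NC(=O)c1ccnc2ccccc12)C(=O)NCc1ccc(C(F)(F)F)cc1` carries quinolin-4-yl in place of 7-methoxy-1-benzofuran-2-yl on a carbonyl carbon. For the measured compounds named here, no measured step tests a quinolin-4-yl group directly; the step of a 19-fold higher number from compound 1 to compound 2 (1.28 log units; beyond the scatter) shows that shifting the nitrogen within such a bicyclic ring can move this assay by a large amount. Compound 4 is therefore expected to show a 1.6-fold lower number from compound 3 to compound 4 (0.19 log units; within the scatter), with wide uncertainty. Compound 4 is estimated at 400 nM, between 100 nM and 1600 nM.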

Compound 4, half-maximal inhibitory concentration: 1030 nM
Compound 4: middle estimate off by 2.6-fold (0.41 log units), on the low side; low and high end bracket the measured number.
By their numbers in this assay, from the lowest: compound 1; then compounds 3, 4 and 2 (each within the scatter of the next, the first and the last beyond it).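

The quinolin-4-yl group shows that the same quinoline, attached to the carbonyl carbon differently, gives a large change: an 11-fold higher number from compound 1 to compound 4 (1.03 log units; beyond the scatter) in this assay. Quinolin-4-yl cannot be separated from the other two groups, with a 1.7-fold higher number from compound 3 to compound 4 (0.22 log units; within the scatter) and a 1.8-fold lower number from compound 2 to compound 4 (0.24 log units; within the scatter), so only quinolin-3-yl stands clearly apart from all the others at this position. Nothing measured here explains this difference. On these data alone, it remains open whether quinolin-2-yl, or a quinolin-3-yl group bearing a methoxy group or an amine, would match compound 1.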